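The compounds below may be only part of what the source reports. "The series", "measured", "known", "first", "only" and "open" are said of these compounds alone.

Three compounds share one core and differ at one of two aromatic rings. In a functional assay on a cell-free system (Platelet, plasma, Homo sapiens) for inhibition (a higher number here means a weaker inhibitor, a lower number a stronger inhibitor), compound 1 `COc1ccc(C(=O)N(CCN2CCC(OCC(=O)O)CC2)c2ccc(C)cc2)cc1` gives 1200 nM, compound 2 `COc1ccc(C(=O)N(CCN2CCC(OCC(=O)O)CC2)c2ccc(Cl)cc2)cc1` gives 3100 nM, and compound 3 `O=C(O)COC1CCN(CCN(C(=O)c2cccc(Cl)c2)c2ccc(Cl)cc2)CC1` gives 350 nM, the lowest of the three. Compound 3 differs from compound 2 by 3-chlorophenyl in place of 4-methoxyphenyl on a carbonyl carbon, and that change gives an 8.9-fold lower number from compound 2 to compound 3 (0.95 log units; beyond the scatter). Compound 4 `Cc1cccc(C(=O)N(CCN2CCC(OCC(=O)O)CC2)c2ccc(Cl)cc2)c1` is not yet measured; it differs from compound 3 by methyl in place of chloro on an aromatic carbon. The same kind of change is already seen once, from compound 2 to compound 1, where methyl in place of chloro on an aromatic carbon gives a 2.6-fold lower number from compound 2 to compound 1 (0.41 log units; beyond the scatter). The two places are not the same, though: in the measured pair the group sits para to a large group, in the new pair it sits meta to a large group, and the neighbouring ring on the carbonyl carbon also differs. A step of similar direction is therefore expected for compound 4 in this assay, but its size is uncertain because a 2.6-fold lower number from compound 2 to compound 1 (0.41 log units; beyond the scatter) was measured on a different ring pattern. Compound 4 is expected to give 200 nM, a step of a 1.8-fold lower number from compound 3 to compound 4 (0.24 log units; within the scatter), with a range from 70 nM to 600 nM.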

Compound 4, half-maximal inhibitory concentration: 310 nM
Compound 4: the middle estimate sits 1.6-fold (0.19 log units) below what was measured, within the range that was stated.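

In this assay, methyl in place of chloro on the 3-substituted ring gives a 1.1-fold lower number from compound 3 to compound 4 (0.05 log units; within the scatter), so compounds 3 and 4 cannot be told apart, whereas 3-methylphenyl in place of 4-methoxyphenyl on the carbonyl carbon gives a 10-fold lower number from compound 2 to compound 4 (1.00 log units; beyond the scatter). The methyl-for-chloro swap has now been read on two cores, and the two readings cannot be separated from each other: the same change on two cores in this assay, a 2.6-fold lower number (0.41 log units; beyond the scatter) from compound 2 to compound 1 and a 1.1-fold lower number (0.05 log units; within the scatter) from compound 3 to compound 4, 2.3-fold (0.36 log units) apart, within the scatter of two such steps. This fits a change that carries over from one core to the other with a similar small effect, but two pairs cannot prove it, and they do not show that the step keeps its size on other cores or what lies behind it.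

The compounds shown leave open what a nitrile or an amine would do at the place now held by methyl or chloro. They also leave open how a longer chain in place of the one carrying the carboxylic acid would read in this assay.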